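Replacing methyl with chloro: from compound 1 to compound 3

The source may report more compounds than this note shows. Statements on the series, on what has been measured and on what is new or still open speak of the compounds shown alone.

In a functional assay on NCI-H460 cells (Homo sapiens) for cytotoxicity, read by MTT assay, with a stated time of 68 h (a higher number here means a weaker inhibitor, a lower number a stronger inhibitor), compound 1 (`Cc1ccccc1-c1cccc(NC(=O)C(Cl)Cl)c1`) stands at 31600 nM and compound 2 (`Cc1cccc(-c2cccc(NC(=O)C(Cl)Cl)c2)c1`) at 24300 nM with the two numbers within the usual scatter of each other, so neither can be ranked over the other. Compound 3 (`O=C(Nc1cccc(-c2ccccc2Cl)c1)C(Cl)Cl`) has not yet been measured. It keeps the core of compound 1 and carries chloro in place of methyl on an aromatic carbon ortho to a large group. Among the measured compounds shown here, no measured pair shows this exchange, so the data offer no direct guide to the size of the step. The expectation therefore starts from compound 1 at 31600 nM and allows for no change beyond the scatter in this assay for this single replacement. The expected step of a 1.3-fold lower number from compound 1 to compound 3 (0.10 log units; within the scatter) is estimated to stay within that scatter. For compound 3 the estimated value is 25000 nM (expected range 11000 nM to 50000 nM).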

Compound 3, half-maximal inhibitory concentration: > 50000 nM
Compound 3 ended at the assay's limit; the forecaster's own chance of this, stated with the estimate: 10%; at least 2.0-fold (0.30 log units) between middle value and limit.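

In this assay compound 3 reads > 50000 nM, which is a limit of the assay and not a number. Chloro in place of methyl on an aromatic carbon ortho to a large group gives an at least 1.5-fold higher number from compound 1 to compound 3 (0.19 log units; that floor lies within the scatter); this is the first reading of any exchange at this position, and it fixes only a floor for the step, not its size. The reading therefore cannot place compound 3 on the scale of the assay: the limit of > 50000 nM in this assay, at which 1 of the 3 values shown sits.

The compounds shown leave open how far the true step lies past that floor, and whether chloro would give a similar reading at the place the methyl holds in compound 2. They also leave open how an amine or a methoxy group at the position of this exchange would read in this assay.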